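A few compounds are considered here, and "the series" means these few. Any claim that something is new, unique, unknown or untested is made for them only; others in the source may bear on it.

Measured compounds:
- compound 1 `Fc1ccc(-c2cn3ccnc3c(-c3ccc4ncn(C5CCCCC5)c4c3)n2)cc1`: 15.5%
- compound 2 `COc1ccccc1-c1cn2ccnc2c(-c2ccc3ncn(C4CCCCC4)c3c2)n1`: 22.2%

In a functional assay on NCI-H522 cells (Homo sapiens) for inhibition, read by sulforhodamine B assay, with a stated time of 48 h, tested at 10 uM (on this read-out higher numbers stand for more inhibition at the one concentration tested (going by the name of the read-out) and lower numbers for less inhibition), compound 1 gives 15.5%, and compound 2 gives 22.2%. Among the compounds with values here, the one step between them, a number 6.7 percentage points higher from compound 1 to compound 2 (within the scatter), lies within the scatter, so the two cannot be told apart on these numbers, and compound 2 stands at the higher of two close values rather than at a clearly higher number.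

Compound 3 `c1csc(-c2cn3ccnc3c(-c3ccc4ncn(C5CCCCC5)c4c3)n2)c1` differs from compound 2 in one place: thiophen-2-yl in place of 2-methoxyphenyl on an aromatic carbon. The change sits on the same aromatic carbon of the shared core that carried the 2-methoxyphenyl in compound 2 and the 4-fluorophenyl in compound 1. Within the data shown here, the only step on record at this position, from compound 1 to compound 2, was within the scatter, and no measured pair shows what a thiophen-2-yl does there. The expectation for this assay is therefore a step of about a number 4.2 percentage points lower from compound 2 to compound 3 (within the scatter), not beyond the scatter in either direction. Compound 3 is estimated at 18%, with a range from 4% to 34%.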

Compound 3, a percentage reported as inhibition, at one concentration (the size of the read-out at that concentration, not a potency): 13.2%
The estimate for compound 3 lay 4.8 percentage points above the measured number; the measured number falls inside the stated range.
By their numbers in this assay, from the lowest: compounds 3, 1 and 2 (each within the scatter of the next).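

Swapping the six-membered aromatic ring for thiophen-2-yl, a five-membered aromatic ring with a sulfur atom, gives a number 9 percentage points lower from compound 2 to compound 3 (within the scatter) and a number 2.3 percentage points lower from compound 1 to compound 3 (within the scatter) in this assay at this carbon of the shared core. Three groups that differ in ring size, in heavy-atom count (5 for thiophen-2-yl against 8 for 2-methoxyphenyl) and in the atoms they carry therefore cannot be told apart here, which a single step between two substituted phenyl rings could not show. Nothing at hand explains why these numbers stay so close, so the result is a description of the read-out and not an account of its cause.

All three groups shown at this position are aromatic rings joined directly to the core, so it remains open whether a group of another kind, such as an amine, a carboxylic acid or a longer alkyl chain, would move the number beyond the scatter. Going by these compounds, it also remains open whether the closeness of these three compounds would hold if the cyclohexyl group elsewhere on the shared core were replaced.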